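Chloro added to the amide aryl of compound 2

This account rests on a few compounds, and the source may have more. Where it says the series, first, only, none or still open, it means among the compounds named here.

Measured so far:
compound 1 `O=C(Nc1cccc(-n2cc(-c3ccncc3)c(-c3ccc(Cl)c(O)c3)n2)c1)Nc1cccc(C(F)(F)F)c1`: 950 nM
compound 2 `COc1cc(-c2nn(-c3cccc(NC(=O)c4cccc(C(F)(F)F)c4)c3)cc2-c2ccncc2)ccc1Cl`: 1230 nM

Of the compounds shown here, two have been measured in a functional assay on PC-3 cells (Homo sapiens) for inhibition, read by sulforhodamine B assay, with a stated time of 48 h; a lower number here means a stronger inhibitor, a higher number a weaker inhibitor. Compound 1 gives 950 nM and compound 2 gives 1230 nM; the two numbers lie within the usual scatter of one another, so neither can be placed above the other. Among the compounds with values here, no pair differing in a single position has been measured, so no step size is known in this assay.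

Compound 3 `COc1cc(-c2nn(-c3cccc(NC(=O)c4ccc(Cl)c(C(F)(F)F)c4)c3)cc2-c2ccncc2)ccc1Cl` differs from compound 2 by chloro in place of hydrogen on an aromatic carbon. Nothing measured in the series shows how such a change acts, so no direction can be read from the data. The expected step from compound 2 to compound 3 is a 1.2-fold lower number from compound 2 to compound 3 (0.09 log units; within the scatter), no step beyond the scatter. Compound 3 is estimated at 1000 nM in this assay, with an expected range from 400 nM to 2500 nM.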

Compound 3, half-maximal inhibitory concentration: 1290 nM
Estimate against measurement, compound 3: 1.3-fold (0.11 log units) below; low and high end bracket the measured number.
By their numbers in this assay, from the lowest: compounds 1, 2 and 3 (each within the scatter of the next).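

In this assay, the change from 3-(trifluoromethyl)phenyl to 4-chloro-3-(trifluoromethyl)phenyl gives a 1.0-fold higher number from compound 2 to compound 3 (0.02 log units; within the scatter), the only step shown in the series between compounds that differ in one place. Chloro, ortho to a trifluoromethyl group and para to a large group, is therefore tolerated at this position on the core of compound 2, with no change that can be told from the scatter. No measurement at hand gives a reason for this result.

As far as these compounds go, whether this position also tolerates an amine or a carboxylic acid remains open, since a single chloro step does not define its limits. Also open, from the compounds shown here alone, are whether the trifluoromethyl group can give way to a nitrile and whether chloro at this position acts the same way on the core of compound 1.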